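This account rests on a few compounds, and the source may have more. Where it says the series, first, only, none or still open, it means among the compounds named here.

Measured so far:
compound 1, `CN1CCC(c2c[nH]c3cnc(NC(=O)c4ccc(F)cc4)cc23)CC1` — 80 nM
compound 2, `COc1ccccc1C(=O)Nc1ccc2[nH]cc(C3CCN(C)CC3)c2n1` — 750 nM

In an assay for binding affinity to 5-hydroxytryptamine receptor 1B (Homo sapiens), read by radioligand binding (on this read-out lower numbers stand for stronger inhibition and higher numbers for weaker inhibition), compound 2 gives 750 nM, the higher of the two numbers; compound 1 gives 80 nM, a gap beyond the scatter. Compound 3, `CN1CCC(c2c[nH]c3ccc(NC(=O)c4cccs4)nc23)CC1`, is not yet measured. It differs from compound 2 by thiophen-2-yl in place of 2-methoxyphenyl on a carbonyl carbon. Among the measured compounds shown here, with no step between measured compounds to lean on, the step of a 3.8-fold lower number from compound 2 to compound 3 (0.57 log units; beyond the scatter) is expected to run toward a lower number, beyond the scatter. For compound 3 the estimate in this assay is 200 nM, with a range from 60 nM to 700 nM.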

Compound 3, inhibition constant: 390 nM
The estimate for compound 3 lay 2.0-fold (0.29 log units) below the measured number, within the range that was stated.
By their numbers in this assay, from the lowest: compound 1; then compounds 3 and 2 (each within the scatter of the next).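

In this assay the step of a 1.9-fold lower number from compound 2 to compound 3 (0.28 log units; within the scatter) comes with thiophen-2-yl in place of 2-methoxyphenyl on a carbonyl carbon. On this core, then, the five-membered aromatic ring with its sulfur atom and the six-membered carbon ring bearing methoxy cannot be told apart in this assay. No evidence at hand bears on this result.

Still open, as far as these compounds go, is whether a saturated ring such as cyclohexyl, or an open alkyl chain, on this carbonyl carbon would shift the number beyond the scatter. The compounds shown also leave open whether an amine there would do so.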